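A few compounds are considered here, and "the series" means these few. Any claim that something is new, unique, unknown or untested is made for them only; others in the source may bear on it.

Measured so far in a physicochemical assay for solubility, read by mass spectrometry, in phosphate buffer, with a stated time of 24 h, at pH 3; on this read-out lower numbers stand for lower solubility and higher numbers for higher solubility:
- compound 1, `O=C(Nc1ccc(C(F)(F)F)cc1)NC1CCN(C(=O)c2ccoc2)CC1`: 6 ug/mL
- compound 2, `O=C(Nc1ccc(C(F)(F)F)cc1)NC1CCN(C(=O)C2CCOC2)CC1`: 50 ug/mL
- compound 3, `O=C(Nc1ccc(C(F)(F)F)cc1)NC1CCN(C(=O)C2CCOCC2)CC1`: 61 ug/mL

Compound 3 holds the highest number of the three in this assay, though its gap to compound 2 is within the scatter; only compound 1 sits clearly apart, with a 10-fold higher number from compound 1 to compound 3 (1.01 log units; beyond the scatter). The replacement of the aromatic ring was the large step in the series: an 8.3-fold higher number from compound 1 to compound 2 (0.92 log units; beyond the scatter) and a 10-fold higher number from compound 1 to compound 3 (1.01 log units; beyond the scatter) are both beyond the scatter, whereas a 1.2-fold higher number from compound 2 to compound 3 (0.09 log units; within the scatter), between the two saturated rings, is not.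

Compound 4, `O=C(Nc1ccc(C(F)(F)F)cc1)NC1CCN(C(=O)C2CCCOC2)CC1`, is not yet measured. It differs from compound 3 by oxan-3-yl in place of oxan-4-yl on a carbonyl carbon. Among the measured compounds shown here, no measured step covers this exact change; the nearest is the saturated-ring swap from compound 2 to compound 3, which stayed within the scatter. For compound 4 the expectation is therefore a step of a 1.1-fold lower number from compound 3 to compound 4 (0.04 log units; within the scatter), that is, none beyond the scatter. Compound 4 is estimated at 55 ug/mL, within a range of 25 ug/mL to 120 ug/mL.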

Compound 4, solubility: 25 ug/mL
Estimate against measurement, compound 4: 2.2-fold (0.34 log units) above; the range from low to high includes it.
By their numbers in this assay, from the lowest: compound 1; then compounds 4, 2 and 3 (each within the scatter of the next, the first and the last beyond it).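

In this assay, moving the attachment point on the same six-membered ring is not a silent change: a 2.4-fold lower number from compound 3 to compound 4 (0.39 log units; beyond the scatter) is a step made with identical atoms, unlike the swap of saturated rings from oxolan-3-yl to oxan-4-yl. Oxan-3-yl is not separated from oxolan-3-yl, since a 2.0-fold lower number from compound 2 to compound 4 (0.30 log units; within the scatter) is the printed step, yet it stays clear of furan-3-yl, with a 4.2-fold higher number from compound 1 to compound 4 (0.62 log units; beyond the scatter) as the step on that side. Nothing measured on these compounds accounts for the gap between oxan-4-yl and oxan-3-yl.

The compounds shown leave open how an amine such as piperidin-4-yl or a carboxylic acid on the carbonyl carbon would read here, and where oxan-2-yl would fall against its two isomers. They also leave open whether the order of oxan-4-yl and oxan-3-yl holds at any pH other than this one.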